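Swapping the Five-Membered Ring on a Shared Thiourea Core

This account rests on a few compounds, and the source may have more. Where it says the series, first, only, none or still open, it means among the compounds named here.

Measured so far:
compound 1 `CCCOC(=O)C1=C(C)NC(=S)NC1c1ccoc1` gives 3%
compound 2 `CC1=C(C(=O)OC(C)(C)C)C(c2ccoc2)NC(=S)N1` gives 19%
compound 3 `CC1=C(C(=O)OCc2ccccc2)C(c2ccoc2)NC(=S)N1` gives 20%

These three compounds were tested in an assay on membranes from HeLa cells for displacement of a labelled ligand from adenosine receptor A3 (Homo sapiens), read by scintillation counting, with a stated time of 180 min, tested at 1 uM; a lower number here means less inhibition, a higher number more inhibition at the concentration tested (going by the name of the read-out). Compound 3 holds the highest number of the three, but compound 2 sits within the usual scatter of it: a number 1 percentage points higher from compound 2 to compound 3 (within the scatter). Against compound 1 the gap is clearer: a number 17 percentage points higher from compound 1 to compound 3 (beyond the scatter), and likewise a number 16 percentage points higher from compound 1 to compound 2 (beyond the scatter).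

Compound 4 `CC1=C(C(=O)OCc2ccccc2)C(c2cccs2)NC(=S)N1` differs from compound 3 in the ring that sits on a saturated ring carbon of the core: thiophen-2-yl in place of furan-3-yl on a saturated ring carbon. Among the compounds with values here, every measured step here changed the ester group, none the five-membered aromatic ring, so no measured step bears directly on this change. With nothing pointing either way, the expectation is a step no larger than the scatter, no change at the digits printed from compound 3 to compound 4 (within the scatter). Compound 4 is therefore estimated at 20%, within 5% to 40%.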

Compound 4, a percentage reported as inhibition, at one concentration (the size of the read-out at that concentration, not a potency): 24%
The estimate for compound 4 lay 4 percentage points below the measured number; the measured number falls inside the stated range.
By their numbers in this assay, from the lowest: compound 1; then compounds 2, 3 and 4 (each within the scatter of the next).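

Within the data shown here, this is the first measured change to the ring on the saturated ring carbon, as every earlier step changed the ester group. With the benzyl ester held fixed in this assay, thiophen-2-yl in place of furan-3-yl gives a number 4 percentage points higher from compound 3 to compound 4 (within the scatter), so this swap of one five-membered aromatic ring for another has no effect that can be told from the scatter. No further evidence bears on this result.

Still open, going by these compounds, is whether a pyridine ring or a cyclohexyl group at this carbon would shift the number beyond the scatter. Also open, on these data alone, is whether thiophen-2-yl gives a similar number alongside the propyl or tert-butyl ester.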